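The compounds below may be only part of what the source reports. "The series", "measured", "known", "first", "only" and "open" are said of these compounds alone.

Series notes. Compound 1 `CCCCN(c1nc2ccccc2o1)[C@H](C)c1ccc(-c2ccccc2-c2nnn[nH]2)cc1` gives 1.8% in an ADME assay on the whole organism (Macaca fascicularis) for pharmacokinetics, read by LC-MS, using cassette dosing; on this read-out lower numbers stand for lower oral bioavailability and higher numbers for higher oral bioavailability. Compound 2 `CCCCN(c1nc2c(C(=O)O)cccc2o1)[C@H](C)c1ccc(-c2ccccc2-c2nnn[nH]2)cc1` gives 8.2% in this assay, and compound 3 `CCCCN(c1nc2c(-c3nccn3C)cccc2o1)[C@H](C)c1ccc(-c2ccccc2-c2nnn[nH]2)cc1` gives 7.5%. Among the three numbers compound 3 stands second highest. The nearest comparison is a number 0.7 percentage points lower from compound 2 to compound 3 (within the scatter), and the furthest is a number 5.7 percentage points higher from compound 1 to compound 3 (within the scatter). The third measured step, a number 6.4 percentage points higher from compound 1 to compound 2 (within the scatter), is also within the scatter, so none of the three groups tried at this aromatic carbon has moved this assay beyond the noise.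

The next compound, compound 4 `CCCCN(c1nc2c(CO)cccc2o1)[C@H](C)c1ccc(-c2ccccc2-c2nnn[nH]2)cc1`, differs from compound 3 in one place: hydroxymethyl in place of 1-methyl-1H-imidazol-2-yl on an aromatic carbon. For the measured compounds named here, the steps that bear on this change are the three above, since each exchanges the group on the same aromatic carbon, and each lies within the scatter. A hydroxymethyl group has not been measured anywhere in this series, so nothing points in either direction. For compound 4 the expected step is a number 1.5 percentage points lower from compound 3 to compound 4 (within the scatter), which is taken to be none beyond the scatter. Compound 4 is therefore estimated at 6% in this assay, with a range from 1.5% to 14%.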

Compound 4, oral bioavailability: 0.8%
Beside the measured number, compound 4's estimate is 5.2 percentage points above it; the measured number lies below the stated range.
By their numbers in this assay, from the lowest: compounds 4, 1, 3 and 2 (each within the scatter of the next).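

Hydroxymethyl adds a fourth group at this aromatic carbon of the six-membered ring, and in this assay it stays within the scatter of all three earlier groups: the exchange for 1-methyl-1H-imidazol-2-yl gives a number 6.7 percentage points lower from compound 3 to compound 4 (within the scatter), the exchange for carboxy gives a number 7.4 percentage points lower from compound 2 to compound 4 (within the scatter), and the exchange for hydrogen gives a number 1 percentage points lower from compound 1 to compound 4 (within the scatter). The largest of these steps, the one from carboxy, is also the largest at this carbon so far and is still printed as within the scatter, so hydrogen, a carboxy group, a ring-bearing group and a small open-chain alcohol group cannot be told apart on this read-out. Nothing among the data available gives a reason for the size of any of these steps.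

Open, from the compounds shown here alone, is whether an aminomethyl group, a primary carboxamide or a longer hydroxyalkyl chain on this carbon would give a step beyond the scatter. Also open, going by these compounds, is whether carboxy or hydroxymethyl on another carbon of this six-membered ring would read differently from the same groups here.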